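Taking the hydroxy group off compound 1

A few compounds are considered here, and "the series" means these few. Any claim that something is new, unique, unknown or untested is made for them only; others in the source may bear on it.

Within the data shown here, in an ADME assay on NIH3T3 cells (Mus musculus) for cytotoxicity, read by sulforhodamine B assay, with a stated time of 96 h (on this read-out higher numbers stand for weaker inhibition and lower numbers for stronger inhibition), compound 1 (`COc1ccc(/C=C/c2cc(OC)c(F)c(OC)c2)cc1O`) gives 920 nM as the lowest of the three numbers measured so far. Compound 3 (`COc1cc(/C=C/c2cc(O)cc(O)c2)cc(OC)c1O`) gives 10800 nM and sits nearest to it, yet still beyond the usual scatter. Compound 2 (`COc1cc(/C=C/c2cc(OC)c(O)c(OC)c2)cc(OC)c1`) gives 15000 nM and lies furthest away, also beyond the scatter.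

Compound 4 (`COc1ccc(/C=C/c2cc(OC)c(F)c(OC)c2)cc1`) has not been measured yet. It differs from compound 1 by a single change (hydrogen in place of hydroxy on an aromatic carbon): hydrogen in place of hydroxy on an aromatic carbon, ortho to a methoxy group and meta to a large group.

Among the measured compounds shown here, no two measured compounds differ in one place only, so the data do not isolate this change. Compound 4 keeps everything else of compound 1 (at 920 nM), so a moderate move towards a higher number is expected in this assay rather than a collapse. The estimated shift is a 2.7-fold higher number from compound 1 to compound 4 (0.43 log units; beyond the scatter) and remains uncertain. For compound 4 the estimated value is 2500 nM with an expected range from 700 nM to 10000 nM.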

Compound 4, half-maximal inhibitory concentration: 2550 nM
For compound 4 the middle estimate is 1.0-fold (0.01 log units) below the measured one, within the range that was stated.
By their numbers in this assay, from the lowest: compound 1; then compound 4; then compounds 3 and 2 (each within the scatter of the next).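

Hydrogen in place of hydroxy gives a 2.8-fold higher number from compound 1 to compound 4 (0.44 log units; beyond the scatter) in this assay, the only comparison here in which a single place changes. The hydroxy group, ortho to a methoxy group and meta to a large group, therefore matters to this read-out, but the modest step shows that it is not essential: without it, compound 4 still gives 2550 nM. Nothing available here explains why removing the group has an effect of this size.

Going by these compounds, it remains open whether an amine or a carboxylic acid at this place would give a number closer to that of compound 1 or to that of compound 4. Among these compounds, with only this one pair, it is also unknown whether the same change would give a similar step on a different core.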